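The compounds below may be only part of what the source reports. "The series", "measured", "known", "first", "only" and "open" are said of these compounds alone.

Values in an ADME assay on MT4 cells (Homo sapiens) for cytotoxicity, read by MTT assay, with a stated time of 4 days; on this read-out lower numbers stand for higher toxicity in this test and higher numbers for lower toxicity in this test:
compound 1 `COC(=O)c1[nH]cc(C(=O)NCc2ccc(F)cc2)c(=O)c1O`: 19000 nM
compound 2 `O=C(O)c1[nH]cc(C(=O)NCc2ccc(F)cc2)c(=O)c1O`: > 200000 nM, a limit of the assay
compound 3 `NC(=O)c1[nH]cc(C(=O)NCc2ccc(F)cc2)c(=O)c1O`: 40000 nM

Of the two actual numbers, compound 3 holds the higher, 40000 nM. Compound 4 `CNC(=O)c1[nH]cc(C(=O)NCc2ccc(F)cc2)c(=O)c1O` carries methyl in place of hydrogen on an amide-type nitrogen. For the measured compounds named here, no measured step makes this exact change. Going by the values given here, two steps bear on it, both removing a methyl: a 2.1-fold higher number from compound 1 to compound 3 (0.32 log units; beyond the scatter), with amino in place of methoxy, and an at least 10-fold higher number from compound 1 to compound 2 (1.02 log units; beyond the scatter), with the methyl lost from the ester. Both went toward higher numbers, so adding a methyl is expected to go the other way. The expected step in this assay is a 2.1-fold lower number from compound 3 to compound 4 (0.32 log units; beyond the scatter), modest and toward a lower number. The estimate for compound 4 is 19000 nM, with a range of 8000 nM to 50000 nM.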

Compound 4, half-maximal cytotoxic concentration: 8500 nM
For compound 4 the middle estimate is 2.2-fold (0.35 log units) above the measured one, and the stated range covers the measured number.
By their numbers in this assay, from the lowest: compound 4; then compound 1; then compound 3. At a limit, above all of these: compound 2.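

In this assay a single methyl on the amide-type nitrogen gives a 4.7-fold lower number from compound 3 to compound 4 (0.67 log units; beyond the scatter) and so shows that this nitrogen is not indifferent to substitution. Methylamino in place of methoxy gives a 2.2-fold lower number from compound 1 to compound 4 (0.35 log units; beyond the scatter) and reverses the direction seen with amino, so compound 4, not the ester, now holds the lowest number of the four. The remaining step, an at least 23-fold lower number from compound 2 to compound 4 (1.37 log units; beyond the scatter) and read from the acid, starts from a limit and not a number: the limit of > 200000 nM in this assay, at which 1 of the 4 values shown sits.

Open, from the compounds shown here alone, is how an ethyl group, a second methyl or a longer chain on this nitrogen would read.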